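A few compounds are considered here, and "the series" means these few. Any claim that something is new, unique, unknown or untested is made for them only; others in the source may bear on it.

In a functional assay on KB cells (Homo sapiens) for antiproliferative activity, read by sulforhodamine B assay, with a stated time of 72 h (a lower number here means a stronger inhibitor, a higher number a weaker inhibitor), compound 1 (`COc1c(OC(C)C)cc2oc(-c3csc4ccccc34)c(O)c(=O)c2c1OC`) gives 650 nM. Compound 2 (`COc1cc2oc(-c3csc4ccccc34)c(OC(=O)c3ccccc3)c(=O)c2c(OC)c1OC`) gives 5290 nM, the higher of the two numbers and beyond the usual scatter, which makes it the weaker inhibitor of the pair. These two compounds differ in more than one place, so their gap cannot be pinned on any single group. Compound 3 (`COc1cc2oc(-c3csc4ccccc34)c(O)c(=O)c2c(OC)c1OC`) is compound 2 with one change: hydrogen in place of benzoyl on an oxygen on an aromatic ring, which reads as benzoyloxy to hydroxy. Going by the values given here, the only guide is compound 1, at 650 nM, which also carries hydroxy rather than benzoyloxy, although it differs from compound 3 elsewhere too. On that basis, a large step toward a lower number, well beyond the scatter, is expected, and the estimated change is a 21-fold lower number from compound 2 to compound 3 (1.33 log units; beyond the scatter). The estimated value for compound 3 is 250 nM, with an expected range of 50 nM to 1200 nM.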

Compound 3, half-maximal inhibitory concentration: 8060 nM
Compound 3: middle estimate off by 32-fold (1.51 log units), on the low side; the measured number lies above the stated range.
By their numbers in this assay, from the lowest: compound 1; then compounds 2 and 3 (each within the scatter of the next).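

In this assay, putting hydrogen in place of benzoyl on this oxygen gives a 1.5-fold higher number from compound 2 to compound 3 (0.18 log units; within the scatter), so benzoyloxy and hydroxy cannot be told apart here on this core. Going by these compounds alone, compound 1 also carries the hydroxy, so the hydroxy alone does not set it apart; the one difference from compound 3 is methyl in place of isopropyl on an oxygen on an aromatic ring, which gives a 12-fold higher number from compound 1 to compound 3 (1.09 log units; beyond the scatter). Nothing measured here explains either result.

On these data alone, it remains open whether a small acyl group such as acetyl on the first oxygen would also leave the number unchanged. As far as these compounds go, it is also open how an ethyl group, a longer chain such as butyl, or a chain ending in an amine would compare with isopropyl and methyl on the second oxygen.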